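The compounds below may be only part of what the source reports. "The series", "measured", "known", "first", "only" and "open" are said of these compounds alone.

Working notes on a small set of thiol-bearing acrylic acids carrying one halogen on the aryl ring. Compound 2 `O=C(O)/C(S)=C/c1ccc(Br)cc1` and compound 1 `O=C(O)/C(S)=C/c1ccc(I)cc1` carry their halogen at one place on the ring, compound 3 `O=C(O)/C(S)=C/c1cccc(Br)c1` and the still unmeasured compound 4 `O=C(O)/C(S)=C/c1cccc(I)c1` at another.

In an assay on isolated protein for inhibition of Calpain-1 catalytic subunit (Sus scrofa) (on this read-out higher numbers stand for weaker inhibition and lower numbers for stronger inhibition), compound 2 gives 1500 nM, compound 1 gives 5200 nM and compound 3 gives 8400 nM. Compound 3 thus stands highest of the three; its gap to compound 1 is within the scatter, its gap to compound 2 beyond it. The difference between the core of compound 2 and the core of compound 3 is not broken down here.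

The change from compound 2 to compound 1 is iodo in place of bromo on an aromatic carbon and produced a 3.5-fold higher number from compound 2 to compound 1 (0.54 log units; beyond the scatter) in this assay. The change from compound 3 to compound 4 is iodo in place of bromo on an aromatic carbon. These are the same kind of change, not the same: in compound 1 the entering iodo sits para to a group of 6 heavy atoms, in compound 4 meta to a group of 6 heavy atoms. Within the data shown here, only one occurrence of the change has been measured, so whether its size carries over to the other place is open.

For compound 4 in this assay the expected step is a 2.4-fold higher number from compound 3 to compound 4 (0.38 log units; beyond the scatter), taking its direction from a 3.5-fold higher number from compound 2 to compound 1 (0.54 log units; beyond the scatter) but with wider uncertainty in size. Compound 4 is accordingly estimated at 20000 nM, with a likely range from 7000 nM to 60000 nM.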

Compound 4, half-maximal inhibitory concentration: 23900 nM
Compound 4: the middle estimate sits 1.2-fold (0.08 log units) below what was measured; the measured number falls inside the stated range.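

In this assay, iodo in place of bromo on an aromatic carbon again gives a higher number, a 2.8-fold higher number from compound 3 to compound 4 (0.45 log units; beyond the scatter), so the change now points the same way on two cores, and each step lies beyond the scatter. Set side by side, the two steps do not differ in size by more than the scatter allows: the same change on two cores in this assay, a 3.5-fold higher number (0.54 log units; beyond the scatter) from compound 2 to compound 1 and a 2.8-fold higher number (0.45 log units; beyond the scatter) from compound 3 to compound 4, 1.2-fold (0.09 log units) apart, within the scatter of two such steps. For this one change, the step read on the core of compound 2 carried over to the core of compound 3 in both direction and size, but two occurrences that share the same acrylic acid and thiol show neither that it holds on a more distant core nor why the number rises.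

The halogens shown are only bromo and iodo, which leaves open whether chloro or fluoro would fall in the same order at either place on the ring, and whether a methoxy or trifluoromethyl group would behave like a halogen there. Also open, on these data alone, is whether the step survives when the carboxylic acid gives way to a methyl ester or the thiol to a methyl thioether.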